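This account rests on a few compounds, and the source may have more. Where it says the series, first, only, none or still open, it means among the compounds named here.

Measured so far, all in a functional assay on SK-MEL-2 cells (Homo sapiens) for inhibition, read by sulforhodamine B assay, with a stated time of 48 h; a higher number here means a weaker inhibitor of growth, a lower number a stronger inhibitor of growth:
- compound 1 `Nc1cc(N)c2nc(-c3ccccc3)c(Oc3ccc(Cl)c(Cl)c3)nc2c1`: 23400 nM
- compound 2 `COc1ccc(CNc2nc3cc(N)cc(N)c3nc2-c2ccccc2)cc1OC`: 30200 nM
- compound 3 `COc1ccc(CNc2nc3cc(N)cc(N)c3nc2-c2ccccc2)cc1`: 28800 nM

Compound 1 holds the lowest of the three numbers, but the gaps to compound 3 and to compound 2 are within the scatter, so no order among the three can be read from them. Among the measured compounds shown here, the single measured step, a 1.0-fold lower number from compound 2 to compound 3 (0.02 log units; within the scatter), is within the scatter as well: removing one methoxy from the aryl part of that side chain left the number where it was.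

The next compound is compound 4 `COc1ccc(Sc2nc3cc(N)cc(N)c3nc2-c2ccccc2)cc1`. Against compound 1 the change is (4-methoxyphenyl)sulfanyl in place of 3,4-dichlorophenoxy on an aromatic carbon. For the measured compounds named here, no measured step touches this position with a sulfur link, and no measured pair swaps the dichlorophenyl pattern for a methoxyphenyl one; the only related step, from compound 2 to compound 3, bears on the methoxy count and was flat. Three side chains of quite different make-up gave numbers within the scatter of one another, so the expectation is that compound 4 also lands in the same band, with a step of a 1.2-fold higher number from compound 1 to compound 4 (0.06 log units; within the scatter) that is expected to be no larger than the scatter in either direction.

For compound 4 the estimate in this assay is 27000 nM, expected within 12000 nM to 60000 nM.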

Compound 4, concentration for total growth inhibition: < 100000 nM
Compound 4 gave a limit, no number; the forecaster's own chance of this, stated with the estimate: 5%; the middle value does not contradict the limit.
By their numbers in this assay, from the lowest: compounds 1, 3 and 2 (each within the scatter of the next).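

In this assay compound 4 gives < 100000 nM, which is a limit and not a number. Among the compounds shown here, the step from compound 1 to compound 4 therefore cannot be read, and this result yields no new step. Still open, on these data alone, is whether (4-methoxyphenyl)sulfanyl in place of 3,4-dichlorophenoxy on the shared core moves the number at all.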